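The source may hold more compounds than are shown below. What is called first, only, known or untested is meant among the compounds shown, and "the series" means these compounds.

Measured so far in a functional assay for inhibition, with Homo sapiens as the target; on this read-out lower numbers stand for stronger inhibition and higher numbers for weaker inhibition:
compound 1, `CN(C)CCCOc1ccc(Nc2nccc(-c3cccnc3)n2)cc1`, gives 600 nM
compound 2, `CC(=O)N(C)c1ccc(Nc2nccc(-c3cccnc3)n2)cc1`, gives 900 nM
compound 3, `CC(C)(C)c1ccc(Nc2nccc(-c3cccnc3)n2)cc1`, gives 600 nM

Compound 3 stands level with compound 1 at the digits given; the two share the lowest number of the three, and compound 2 lies furthest off, though that gap is within the scatter. All three differ only in the group on one aromatic carbon of the shared core, and none of the swaps among them moved the read-out beyond the scatter: a 1.5-fold higher number from compound 1 to compound 2 (0.18 log units; within the scatter); no change at the digits printed from compound 1 to compound 3 (within the scatter); a 1.5-fold lower number from compound 2 to compound 3 (0.18 log units; within the scatter).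

Compound 4, `CNc1ccc(Nc2nccc(-c3cccnc3)n2)cc1`, is not yet measured. It changes the same position: methylamino in place of tert-butyl on an aromatic carbon. Among the measured compounds shown here, the entering group is the first at this carbon to carry a hydrogen-bond donor, so the measured steps cover it only in part; still, none of them hints that this position is sensitive. The expectation in this assay is therefore a step within the scatter, a 1.2-fold higher number from compound 3 to compound 4 (0.07 log units; within the scatter). Compound 4 is estimated at 700 nM, with a range of 300 nM to 1500 nM.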

Compound 4, half-maximal inhibitory concentration: 2100 nM
Estimate against measurement, compound 4: 3.0-fold (0.48 log units) below; the whole stated range lies below it.
By their numbers in this assay, from the lowest: compounds 1, 3 and 2 (each within the scatter of the next); then compound 4.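

In this assay, among the compounds shown here, this position proves sensitive after all: methylamino is the first group at this aromatic carbon to move the read-out beyond the scatter (a 3.5-fold higher number from compound 3 to compound 4 (0.54 log units; beyond the scatter); a 3.5-fold higher number from compound 1 to compound 4 (0.54 log units; beyond the scatter)). Taking the acetyl off the nitrogen of compound 2 is also enough to do so (a 2.3-fold higher number from compound 2 to compound 4 (0.37 log units; beyond the scatter)), so 3-(dimethylamino)propoxy, tert-butyl and acetyl(methyl)amino cannot be told apart here, while compound 4, the only one with a hydrogen-bond donor on this carbon, stands apart. No supporting data explain this step, and the series does not separate the donor from the smaller heavy-atom count of methylamino.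

From the compounds shown here alone, it remains open whether the step follows the hydrogen on the nitrogen or the small size of the group. Dimethylamino, a plain amine and methoxy at this carbon would bear on that question.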